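The compounds below may be only part of what the source reports. "The series", "measured", "known", "first", "only" and "open" are said of these compounds alone.

Measured compounds:
- compound 1, `CN(C)CCN(CCN(C)C)c1cccc(C(=O)N2CCc3ccc(OS(N)(=O)=O)cc3C2)c1`: 0%
- compound 2, `CC(C)CCN(CCC(C)C)c1cccc(C(=O)N2CCc3ccc(OS(N)(=O)=O)cc3C2)c1`: 32.3%
- compound 3, `NS(=O)(=O)Oc1ccc2c(c1)CN(C(=O)c1ccc(N(CCCO)Cc3ccccc3)cc1)CC2`: 5.7%

These three compounds were tested in an assay on HEK293 cells for inhibition of Steryl-sulfatase (Homo sapiens), tested at 0.1 uM; a higher number here means a stronger effect of the compound at the concentration tested, a lower number a weaker effect. Among them compound 2 stands highest, with compound 3 giving 5.7% and compound 1 giving 0%, both beyond the scatter below it. Going by the values given here, the one step measured between compounds that differ in a single place runs from compound 1 to compound 2, where a number 32.3 percentage points higher from compound 1 to compound 2 (beyond the scatter); it shows that the group on this aromatic carbon can move the readout strongly.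

Compound 4, `CCCN(CCC)c1cccc(C(=O)N2CCc3ccc(OS(N)(=O)=O)cc3C2)c1`, has not yet been measured. It keeps the shared core of compound 2 and differs in one place: dipropylamino in place of diisopentylamino on an aromatic carbon. Among the compounds with values here, no measured step shortens such a chain, so the direction of the change rests only on the observation that compound 2 carries the longest chains and the highest number. The expectation for compound 4 in this assay is therefore a somewhat lower number, a step of a number 17.3 percentage points lower from compound 2 to compound 4 (beyond the scatter), which may or may not exceed the scatter. Compound 4 is estimated at 15%, within a range of 0% to 35%.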

Compound 4, a percentage reported as inhibition, at one concentration (the size of the read-out at that concentration, not a potency): 8.3%
For compound 4 the middle estimate is 6.7 percentage points above the measured one; measured number inside the range.
By their numbers in this assay, from the lowest: compounds 1, 3 and 4 (each within the scatter of the next); then compound 2.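

On this aromatic carbon, chain size alone can shift the readout in this assay: exchanging diisopentylamino for dipropylamino, with no change in the counted hydrogen-bond donors, acceptors or charge, gives a number 24 percentage points lower from compound 2 to compound 4 (beyond the scatter). Replacing bis(2-(dimethylamino)ethyl)amino with dipropylamino gives a number 8.3 percentage points higher from compound 1 to compound 4 (within the scatter), so removing the dimethylamino ends does not by itself reproduce the high number of compound 2, and only the larger diisopentylamino stands apart here. No available evidence explains this difference.

Two features change together in this step, chain length and branching, so a straight dipentylamino group would be needed to separate them. As far as these compounds go, whether the number keeps rising with a longer chain, such as dihexylamino, also remains open.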